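Taking the 4-methylphenoxy end off the chain

The compounds below may be only part of what the source reports. "The series", "measured", "known", "first", "only" and "open" are said of these compounds alone.

Going by the values given here, in a functional assay on PC-3 cells (Homo sapiens) for antiproliferative activity, read by MTT assay, with a stated time of 48 h (a lower number here means a stronger inhibitor of growth, a higher number a weaker inhibitor of growth), compound 3 (`Cc1ccc(OCCCCN(Cc2ccc(C(=O)NO)cc2)c2ncc(-c3ccc(C)cc3)s2)cc1`) gives 1220 nM, the lowest number of the three measured so far. Compound 1 (`Cc1ccc(-c2cnc(N(Cc3ccc(C(=O)NO)cc3)CC(C)C)s2)cc1`) gives 9340 nM and compound 2 (`CCCCCCCCN(Cc1ccc(C(=O)NO)cc1)c1ncc(-c2ccc(C)cc2)s1`) gives 13300 nM, and neither carries the 4-methylphenoxy group. Compound 4 (`CCCN(Cc1ccc(C(=O)NO)cc1)c1ncc(-c2ccc(C)cc2)s1`) has hydrogen in place of (4-methylphenoxy)methyl on a saturated chain carbon, three bonds along the chain from a nitrogen on an aromatic ring, so that 4-(4-methylphenoxy)butyl becomes propyl: hydrogen in place of (4-methylphenoxy)methyl on a saturated chain carbon, three bonds along the chain from a nitrogen on an aromatic ring.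

Among the compounds with values here, two measured steps bear most directly on this change: a 7.7-fold lower number from compound 1 to compound 3 (0.88 log units; beyond the scatter) and an 11-fold lower number from compound 2 to compound 3 (1.04 log units; beyond the scatter). Both run towards the 4-methylphenoxy chain, so the change here runs the opposite way. The alkyl groups of the other two compounds hardly separate them, with a 1.4-fold higher number from compound 1 to compound 2 (0.15 log units; within the scatter). Propyl is therefore expected to fall with that pair, although no chain this short has been measured. The expected change is an 8.2-fold higher number from compound 3 to compound 4 (0.91 log units; beyond the scatter), a rise comparable in size to those two steps. The estimate for compound 4 is 10000 nM, with an expected range of 4500 nM to 22000 nM.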

Compound 4, concentration for 50% growth inhibition: 9160 nM
Compound 4: the middle estimate sits 1.1-fold (0.04 log units) above what was measured, within the range that was stated.
By their numbers in this assay, from the lowest: compound 3; then compounds 4, 1 and 2 (each within the scatter of the next).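

In this assay, going by these compounds alone, cutting the (4-methylphenoxy)methyl end back to hydrogen gives a 7.5-fold higher number from compound 3 to compound 4 (0.88 log units; beyond the scatter) and so tests the loss of that end directly on one chain, where the earlier steps compared compound 3 only with other alkyl groups. The propyl chain of compound 4 also stays level with the other two alkyl chains, with a 1.5-fold lower number from compound 2 to compound 4 (0.16 log units; within the scatter) and a 1.0-fold lower number from compound 1 to compound 4 (0.01 log units; within the scatter), so among compounds 1, 2 and 4 the alkyl group makes no difference beyond the scatter, and only compound 3 stands apart. No measurement shown here explains the gain that comes with the 4-methylphenoxy end.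

The compounds shown leave open whether the gain rests on the aromatic ring or on the ether oxygen, which a 4-phenylbutyl or 4-methoxybutyl chain would separate. Also open, on these data alone, is how a chain ending in an amine or a carboxylic acid would compare.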